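Butyl to Propyl: A Small Step in Cell Growth Inhibition

The source may hold more compounds than are shown below. What is called first, only, known or untested is meant among the compounds shown, and "the series" means these compounds.

Compound 1 `CCCCn1cnc2c(NCc3ccc(C(=O)Nc4ccccc4N)cc3)nc(Cl)nc21` and compound 2 `Nc1ccccc1NC(=O)c1ccc(COCNc2nc(Nc3cccc(Cl)c3)c3ncn(C4CCCC4)c3n2)cc1` were both examined in a functional assay on HCT-116 cells (Homo sapiens) for antiproliferative activity, read by CCK-8 assay, with a stated time of 72 h, tested at 2 uM; a higher number here means a stronger effect of the compound at the concentration tested, a lower number a weaker effect. In this assay compound 1 gives 4.89%, the lowest of the two numbers recorded, while compound 2 gives 29.2%, a value that lies beyond the scatter above it. Compound 3 `CCCn1cnc2c(NCc3ccc(C(=O)Nc4ccccc4N)cc3)nc(Cl)nc21` differs from compound 1 in a single place: hydrogen in place of methyl on a saturated chain carbon, three bonds along the chain from an aromatic nitrogen. Within the data shown here, no pair of measured compounds shows this change, so the data give no direct guide. Such a short trimming of the chain is expected to leave the number close to where it stands, and the step of a number 1.1 percentage points higher from compound 1 to compound 3 (within the scatter) is expected to fall within the scatter. Compound 3 is therefore estimated at 6%, with a range from -4% to 16%.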

Compound 3, a percentage reported as inhibition, at one concentration (the size of the read-out at that concentration, not a potency): 28.5%
The estimate for compound 3 lay 22.5 percentage points below the measured number, outside the stated range (above it).
By their numbers in this assay, from the lowest: compound 1; then compounds 3 and 2 (each within the scatter of the next).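

In this assay the change from butyl to propyl brings a number 23.6 percentage points higher from compound 1 to compound 3 (beyond the scatter) and so shows that this saturated chain, trimmed three bonds along from an aromatic nitrogen, is not a silent place in the molecule. Among these compounds, this is the first step in the set that isolates a single change, and it rests on this one pair alone. Nothing available explains the size of the step.

On these data alone, whether ethyl or pentyl on the same aromatic nitrogen would lift or lower the number remains open. So does whether an amine at the end of the chain would be tolerated there.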